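The source may hold more compounds than are shown below. What is called first, only, known or untested is meant among the compounds shown, and "the series" means these compounds.

Measured compounds: compound 1 `COc1cc2c(Oc3ccc(NC(=O)c4nn(-c5ccccc5OC(F)(F)F)c(=O)cc4C)cc3F)ccnc2cc1OCCCN1CCC(C)CC1` gave 800 nM in a functional assay on U-87MG ATCC cells (Homo sapiens) for inhibition, read by MTT assay, with a stated time of 72 h; a lower number here means a stronger inhibitor, a higher number a weaker inhibitor; compound 2 `COc1cc2c(Oc3ccc(NC(=O)c4nn(-c5ccccc5OC(F)(F)F)c(=O)cc4C)cc3F)ccnc2cc1OCCCN1CCN(C)CC1` gave 1440 nM in this assay; compound 3 `COc1cc2c(Oc3ccc(NC(=O)c4nn(-c5ccc(Cl)cc5)c(=O)cc4C)cc3F)ccnc2cc1OCCCN1CCC(C)CC1` gave 1350 nM in this assay.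

Compound 2 differs from compound 1 by 4-methylpiperazin-1-yl in place of 4-methylpiperidin-1-yl on a saturated chain carbon, three bonds along the chain from an oxygen on an aromatic ring, and the step was a 1.8-fold higher number from compound 1 to compound 2 (0.26 log units; within the scatter). Compound 3 differs from compound 1 in its core by 4-chlorophenyl in place of 2-(trifluoromethoxy)phenyl on an aromatic nitrogen, with a step of a 1.7-fold higher number from compound 1 to compound 3 (0.23 log units; within the scatter). Compound 4 `COc1cc2c(Oc3ccc(NC(=O)c4nn(-c5ccc(Cl)cc5)c(=O)cc4C)cc3F)ccnc2cc1OCCCN1CCN(C)CC1` has not yet been measured; it differs from compound 3 by 4-methylpiperazin-1-yl in place of 4-methylpiperidin-1-yl on a saturated chain carbon, three bonds along the chain from an oxygen on an aromatic ring, the same change that leads from compound 1 to compound 2, at the same place. On the core of compound 3 the step is expected to be a 1.8-fold higher number from compound 3 to compound 4 (0.25 log units; within the scatter), resting on the step of a 1.8-fold higher number from compound 1 to compound 2 (0.26 log units; within the scatter) seen on the core of compound 1. Compound 4 is therefore expected to give about 2400 nM in this assay, between 1100 nM and 5200 nM.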

Compound 4, half-maximal inhibitory concentration: 1560 nM
Estimate against measurement, compound 4: 1.5-fold (0.19 log units) above; measured number inside the range.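

In this assay, 4-methylpiperazin-1-yl in place of 4-methylpiperidin-1-yl gives a 1.2-fold higher number from compound 3 to compound 4 (0.06 log units; within the scatter), and this step agrees with the one on the core of compound 1: the same change on two cores in this assay, a 1.8-fold higher number (0.26 log units; within the scatter) from compound 1 to compound 2 and a 1.2-fold higher number (0.06 log units; within the scatter) from compound 3 to compound 4, 1.6-fold (0.19 log units) apart, within the scatter of two such steps. With the 4-methylpiperazin-1-yl group in place, 4-chlorophenyl in place of 2-(trifluoromethoxy)phenyl gives a 1.1-fold higher number from compound 2 to compound 4 (0.03 log units; within the scatter), which also agrees with its earlier step: the same change on two cores in this assay, a 1.7-fold higher number (0.23 log units; within the scatter) from compound 1 to compound 3 and a 1.1-fold higher number (0.03 log units; within the scatter) from compound 2 to compound 4, 1.6-fold (0.19 log units) apart, within the scatter of two such steps. All these steps lie within the scatter: nothing suggests that either change behaves differently on the two cores, but no real effect of either change is shown that could be said to carry over.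

The compounds shown leave open whether this agreement would hold for other amines on the chain, such as morpholine or dimethylamine, or for a longer chain than the propyl one. They also leave open whether another group on the aromatic nitrogen, such as unsubstituted phenyl, would give a step beyond the scatter.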